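Swapping Cyclopropyl for 3-Bromophenyl in a Weakly Cytotoxic Series

This account rests on a few compounds, and the source may have more. Where it says the series, first, only, none or still open, it means among the compounds named here.

Of the compounds shown here, three sharing one core have been tested in a functional assay on MCF7 cells (Homo sapiens) for cytotoxicity, read by MTT assay, with a stated time of 48 h; a lower number here means a stronger inhibitor, a higher number a weaker inhibitor. Compound 1 `COc1cc(-c2nnc3n2NC(c2ccco2)C(C(=O)c2ccc(F)c(F)c2)S3)cc(OC)c1OC` gives 73200 nM. Compound 2 `COc1ccc(C(=O)C2Sc3nnc(-c4cc(OC)c(OC)c(OC)c4)n3NC2c2ccco2)cc1` shows only > 100000 nM, which is a limit of the assay rather than a number. Compound 3 `COc1cc(-c2nnc3n2NC(c2ccco2)C(C(=O)C2CC2)S3)cc(OC)c1OC` likewise reaches only the limit > 100000 nM. Two of the three values thus sit at the limit of > 100000 nM in this assay, at which 2 of the 3 values shown sit. Compound 4 `COc1cc(-c2nnc3n2NC(c2ccco2)C(C(=O)c2cccc(Br)c2)S3)cc(OC)c1OC` is not yet measured and differs from compound 3 by 3-bromophenyl in place of cyclopropyl on a carbonyl carbon. Within the data shown here, the steps that bear on this change are an at least 1.3-fold higher number from compound 1 to compound 3 (0.13 log units; that floor lies within the scatter) and an at least 1.3-fold higher number from compound 1 to compound 2 (0.13 log units; that floor lies within the scatter), both small, while a step that the two limits leave unreadable from compound 2 to compound 3 cannot be read. An aromatic group in this position may bring compound 4 toward compound 1, but the evidence is thin. Compound 4 is expected near 100000 nM, within 40000 nM to 300000 nM. The estimated step of a number no higher from compound 3 to compound 4 (the limit leaves the size open) stays within scatter.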

Compound 4, half-maximal inhibitory concentration: 91800 nM
The estimate for compound 4 lay 1.1-fold (0.04 log units) above the measured number; measured number inside the range.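

Compound 4 gives a measured number where compound 3 has only a limit, yet replacing cyclopropyl with 3-bromophenyl amounts to an at least 1.0-fold lower number from compound 3 to compound 4 (0.03 log units; that floor lies within the scatter). Replacing the other aromatic groups leaves the same picture: an at least 1.0-fold lower number from compound 2 to compound 4 (0.03 log units; that floor lies within the scatter), and a 1.3-fold higher number from compound 1 to compound 4 (0.10 log units; within the scatter). So no group tested on this carbonyl carbon separates from the others beyond the scatter, and the series stays weak, with two compounds at a limit: the limit of > 100000 nM in this assay, at which 2 of the 4 values shown sit.

The step between those two limits cannot be read. As far as these compounds go, whether an amine or a carboxylic acid on a longer chain at this carbonyl carbon would give a clearly stronger number remains open.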